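Aryl substituent steps in the mast cell series

This account rests on a few compounds, and the source may have more. Where it says the series, first, only, none or still open, it means among the compounds named here.

compound 1 `CCOc1ccc(N/N=C2\CCC(C)n3c2ncc(C(=O)O)c3=O)cc1` 17600 nM
compound 2 `CCCCc1ccc(N/N=C2\CCC(C)n3c2ncc(C(=O)O)c3=O)cc1` 1700 nM
compound 3 `CC1CC/C(=N\Nc2ccc(C3CC3)cc2)c2ncc(C(=O)O)c(=O)n21` 1000 nM

In a functional assay (mast cells) for inhibition, with Rattus norvegicus as the target (on this read-out higher numbers stand for an effect only at larger amounts of compound and lower numbers for an effect already at smaller amounts), compound 3 stands at 1000 nM, within the scatter of compound 2, and both lie well under compound 1. Compound 4 `CC1CC/C(=N\Nc2ccc(CC(=O)O)cc2)c2ncc(C(=O)O)c(=O)n21` has carboxymethyl in place of cyclopropyl on an aromatic carbon, para to a large group (carboxymethyl in place of cyclopropyl on an aromatic carbon). Going by the values given here, three measured steps concern this same place. Two were large, a 10-fold lower number from compound 1 to compound 2 (1.02 log units; beyond the scatter) and an 18-fold lower number from compound 1 to compound 3 (1.25 log units; beyond the scatter), while a 1.7-fold lower number from compound 2 to compound 3 (0.23 log units; within the scatter) stayed within the scatter. Ethoxy, the only measured group here holding oxygen, gave the high number of compound 1 at 17600 nM, and carboxymethyl also holds oxygen. A large step to a higher number is therefore expected, a 9.0-fold higher number from compound 3 to compound 4 (0.95 log units; beyond the scatter). For compound 4 the estimated value is 9000 nM, with an expected range from 2000 nM to 40000 nM.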

Compound 4, half-maximal effective concentration: 3400 nM
Estimate against measurement, compound 4: 2.6-fold (0.42 log units) above; the measured number falls inside the stated range.
By their numbers in this assay, from the lowest: compounds 3, 2 and 4 (each within the scatter of the next, the first and the last beyond it); then compound 1.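

In this assay, oxygen in the group at this aromatic carbon does not by itself give a number as high as that of compound 1: carboxymethyl stands clearly under ethoxy (a 5.2-fold lower number from compound 1 to compound 4 (0.71 log units; beyond the scatter)) and cannot be told apart from butyl (a 2.0-fold higher number from compound 2 to compound 4 (0.30 log units; within the scatter)). Against cyclopropyl, however, carboxymethyl still gives a higher number (a 3.4-fold higher number from compound 3 to compound 4 (0.53 log units; beyond the scatter)). Nothing available explains these differences. As far as these compounds go, it remains open whether an aminomethyl group or the methyl ester of carboxymethyl at this place would give a number like that of compound 4.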